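Aryl variation on the shared core: outlook for compound 4

This account rests on a few compounds, and the source may have more. Where it says the series, first, only, none or still open, it means among the compounds named here.

Measured so far in a functional assay on MCF7 cells (Homo sapiens) for antiproliferative activity, read by MTT assay, with a stated time of 72 h; a lower number here means a stronger inhibitor, a higher number a weaker inhibitor:
compound 1 `COc1cccc(-c2ccc3ncn(-c4cc(OC)c(OC)c(OC)c4)c3c2)c1` — 1610 nM
compound 2 `COc1ccccc1-c1ccc2ncn(-c3cc(OC)c(OC)c(OC)c3)c2c1` — 1750 nM
compound 3 `COc1cc(-n2cnc3ccc(-c4ccc(C(C)=O)cc4)cc32)cc(OC)c1OC` — 1540 nM

All three numbers sit close together. Compound 3 gives the lowest of the three, but the gaps to compound 1 and to compound 2 are both within the scatter, so no order among the three can be read from these values.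

Compound 4 `COc1cc(-n2cnc3ccc(-c4cccc(Cl)c4)cc32)cc(OC)c1OC` keeps the shared core and changes only the aryl group at the same place that was varied among compounds 1 to 3: 3-chlorophenyl in place of 4-acetylphenyl on an aromatic carbon.

Going by the values given here, the steps that bear on this are those that exchanged the aryl group at this position: a 1.0-fold lower number from compound 1 to compound 3 (0.02 log units; within the scatter) and a 1.1-fold lower number from compound 2 to compound 3 (0.06 log units; within the scatter), with a 1.1-fold higher number from compound 1 to compound 2 (0.04 log units; within the scatter) for the remaining pair. None of the three moved the number beyond the scatter. A fourth aryl group at the same place is therefore expected to behave the same way, so the estimated step is a 1.0-fold higher number from compound 3 to compound 4 (0.02 log units; within the scatter), with no direction beyond the scatter. The estimate for compound 4 is 1600 nM, expected to fall between 700 nM and 3600 nM.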

Compound 4, half-maximal inhibitory concentration: 3120 nM
Beside the measured number, compound 4's estimate is 2.0-fold (0.29 log units) below it; low and high end bracket the measured number.
By their numbers in this assay, from the lowest: compounds 3, 1, 2 and 4 (each within the scatter of the next, the first and the last beyond it).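

In this assay, going by these compounds alone, this aryl position is no longer flat: exchanging the group here gives, for the first time, a step beyond the scatter, with 3-chlorophenyl in place of 4-acetylphenyl giving a 2.0-fold higher number from compound 3 to compound 4 (0.31 log units; beyond the scatter). The separation holds against compound 3 only, since the 2-methoxyphenyl exchange gives a 1.8-fold higher number from compound 2 to compound 4 (0.25 log units; within the scatter) and the exchange of chloro for methoxy on the shared 3-substituted phenyl gives a 1.9-fold higher number from compound 1 to compound 4 (0.29 log units; within the scatter), and both remain within the scatter. Within the data shown here, the one step beyond the scatter changes the substituent and its place on the phenyl ring together, so the two contributions cannot be separated, and no available measurement explains the step.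

From the compounds shown here alone, a 4-chlorophenyl or 3-acetylphenyl group would separate the substituent from its place on the ring, and whether either stays near compound 3 or near compound 4 remains open. Also open, going by these compounds, is how this position responds to an aminophenyl group, a carboxylic acid on the phenyl ring, or a longer chain in place of the aryl group.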